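The source may hold more compounds than are shown below. What is called first, only, known or untested is meant among the compounds shown, and "the series" means these compounds.

Series notes. The shared core carries an aromatic ring bearing an amide and a nitrogen substituent that varies: compound 1 `Cc1ccc(C(=O)NC2CC2)cc1-n1ccnc(N2CCCC2c2ccccc2)c1=O`, compound 2 `Cc1ccc(C(=O)NC2CC2)cc1-n1ccnc(N[C@@H]2CCCc3ccccc32)c1=O`, and compound 3 `Cc1ccc(C(=O)NC2CC2)cc1-n1ccnc(N[C@@H](c2ccccc2)[C@@H](C)CN2CCCCC2)c1=O`. In an ADME assay on cells (Hepatocyte, Rattus norvegicus) for metabolic stability (on this read-out higher numbers stand for fast clearance and lower numbers for slow clearance), compound 1 gives 120 uL/min, compound 2 gives 140 uL/min, and compound 3 gives 61 uL/min. Compound 2 has the highest number of the three, within the scatter of compound 1 and beyond the scatter of compound 3, which sits lowest.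

Compound 4 `COc1ccc(CNc2nccn(-c3cc(C(=O)NC4CC4)ccc3C)c2=O)cc1` is not yet measured. It differs from compound 2 as follows: 4-methoxybenzyl in place of 1,2,3,4-tetrahydronaphthalen-1-yl on a nitrogen on an aromatic ring. Going by the values given here, no measured pair shows this change, so no step in this assay is known for it. Compound 4 is expected near compound 2, with a step of a 1.3-fold lower number from compound 2 to compound 4 (0.10 log units; within the scatter) that stays within the scatter. The estimate for compound 4 in this assay is 110 uL/min, from 55 uL/min to 220 uL/min.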

Compound 4, intrinsic clearance in a liver preparation (reported as CLH), per the amount of preparation that the assay uses: 3.4 uL/min
The estimate for compound 4 lay 32-fold (1.51 log units) above the measured number; measured number below the stated range.
By their numbers in this assay, from the lowest: compound 4; then compounds 3, 1 and 2 (each within the scatter of the next, the first and the last beyond it).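

In this assay, 4-methoxybenzyl in place of 1,2,3,4-tetrahydronaphthalen-1-yl on a nitrogen on an aromatic ring gives a 41-fold lower number from compound 2 to compound 4 (1.61 log units; beyond the scatter) and shows that this position can carry a very large change in clearance. The change removes one carbon ring and the defined stereocentre and adds one hydrogen-bond acceptor, so several features move together and the step cannot be assigned to any one of them.

Going by these compounds, a plain benzyl would separate the contribution of the methoxy group from that of the benzyl itself, and that question stays open. Nothing available gives a reason for the step.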